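Swapping the thiazole for a cyanophenyl on the shared core

This account rests on a few compounds, and the source may have more. Where it says the series, first, only, none or still open, it means among the compounds named here.

Measured so far in a functional assay on CHO-K1 cells for antagonist activity at adenosine receptor A1 (Homo sapiens), read by a beta-galactosidase reporter and cAMP accumulation, with stated times of 15 min and 6 h; a higher number here means a weaker inhibitor, a lower number a stronger inhibitor:
- compound 1, `Cc1csc(-c2nc(N)c3cc(Cc4ccccc4)sc3n2)n1`: 1490 nM
- compound 2, `C=C(c1ccccc1)c1cc2c(N)nc(-c3nc(C)cs3)nc2s1`: > 594 nM

Compound 2 stands at a limit in this assay, and its value of > 594 nM is therefore not a number but the edge of what the measurement could read. Compound 3, `C=C(c1ccccc1)c1cc2c(N)nc(-c3cccc(C#N)c3)nc2s1`, has not been measured yet. It differs from compound 2 in one place: 3-cyanophenyl in place of 4-methyl-1,3-thiazol-2-yl on an aromatic carbon. Going by the values given here, only one measured step exists, a step that the limit leaves unreadable from compound 1 to compound 2, and it concerns a different part of the molecule, so no measured step bears on the present change; its size stays hidden because of the limit of > 594 nM in this assay, at which 1 of the 2 values shown sits. With compound 2 already at a limit, compound 3 is expected to remain weak, around 2000 nM, with a likely range from 500 nM to 10000 nM. The step that the limit leaves unreadable from compound 2 to compound 3 is thus expected to be small or none beyond the scatter.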

Compound 3, inhibition constant: > 1000 nM
Compound 3: only a limit was reported (the forecaster's own chance of this, stated with the estimate: 50%); the middle value does not contradict the limit.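

Compound 2 and compound 3 both stand at a limit in this assay, and the step between them cannot be read. The compounds shown leave open how 3-cyanophenyl and 4-methyl-1,3-thiazol-2-yl compare on the shared core, and what true values lie behind these two limits.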